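Swapping Ethynyl for 1-Bromoethyl on a Carbonyl Carbon

The source may report more compounds than this note shows. Statements on the series, on what has been measured and on what is new or still open speak of the compounds shown alone.

Of the compounds shown here, three on a shared core have been tested in a functional assay on MGC-803 cells (Homo sapiens) for inhibition, read by MTT assay, with a stated time of 48 h; a lower number here means a stronger inhibitor, a higher number a weaker inhibitor. Compound 1 `C#CC(=O)N(Cc1ccc(OC)c(O)c1)c1cc(OC)c(OC)c(OC)c1` gives 170 nM, the second highest of the three numbers. Compound 3 `C/C=C/C(=O)N(Cc1ccc(OC)c(N)c1)c1cc(OC)c(OC)c(OC)c1` gives 150 nM, which lies within the scatter of compound 1, so the two cannot be separated. Compound 2 `COc1cc(NCc2cccc(O)c2)cc(OC)c1OC` gives 57600 nM, far weaker and well beyond the scatter. Compound 4 `COc1ccc(CN(C(=O)C(C)Br)c2cc(OC)c(OC)c(OC)c2)cc1O` awaits measurement. It differs from compound 1 in one place: 1-bromoethyl in place of ethynyl on a carbonyl carbon. Within the data shown here, no measured pair shows this exact change, so its size is open. Because compound 1 gives 170 nM and compound 3 gives 150 nM, compound 4 is expected to stay near them, with a step of a 1.8-fold higher number from compound 1 to compound 4 (0.25 log units; within the scatter) of modest size toward a slightly higher number. Compound 4 is estimated at 300 nM, between 100 nM and 1000 nM.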

Compound 4, half-maximal inhibitory concentration: 120 nM
Compound 4: the middle estimate sits 2.5-fold (0.40 log units) above what was measured; the measured number falls inside the stated range.
By their numbers in this assay, from the lowest: compounds 4, 3 and 1 (each within the scatter of the next); then compound 2.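

Replacing ethynyl with 1-bromoethyl on the carbonyl carbon gives a 1.4-fold lower number from compound 1 to compound 4 (0.15 log units; within the scatter) in this assay, so the two compounds cannot be told apart. In this pair, the triple bond can be lost and a bromine-bearing group put in its place without a measurable change in the number. Nothing measured here explains why the two groups read alike.

On these data alone, whether an amine, a carboxylic acid or a longer chain on this carbonyl carbon would keep the number in the same range remains open. So does the result of an ethyl group, which would show what the bromine contributes.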